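This account rests on a few compounds, and the source may have more. Where it says the series, first, only, none or still open, it means among the compounds named here.

Values measured in a functional assay on NCI-H460 cells (Homo sapiens) for inhibition, read by MTT assay, with a stated time of 24 h, tested at 0.1 ug/mL; a lower number here means less inhibition of growth, a higher number more inhibition of growth at the concentration tested:
- compound 1 `CC(=O)SCCC(CCCCC(=O)O)SC(C)=O`: 9.96%
- compound 2 `O=C(CCCCC1CCSS1)Nc1ccccc1Cl`: 8%
- compound 3 `O=C(CCCCC(S)CCS)Nc1cccc(Cl)c1`: 9.78%

These three values lie within the scatter of each other, so compound 1 cannot be separated from compound 2 or compound 3. Compound 4 `CC(=O)SCCC(CCCCC(=O)Nc1ccccc1Cl)SC(C)=O` has not yet been measured. It carries (2-chlorophenyl)amino in place of hydroxy on a carbonyl carbon. Going by the values given here, no measured pair isolates this change, but compound 2, at 8%, also bears (2-chlorophenyl)amino on a carbonyl carbon. No step beyond the scatter is therefore expected in this assay, in either direction. The expected step is a number 0 percentage points higher from compound 1 to compound 4 (within the scatter). For compound 4 the estimated value is 10%, with an expected range from 3% to 20%.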

Compound 4, percent growth inhibition at one concentration: 16.6%
Estimate against measurement, compound 4: 6.6 percentage points below; the range from low to high includes it.
By their numbers in this assay, from the lowest: compounds 2, 3, 1 and 4 (each within the scatter of the next).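

In this assay, going by these compounds alone, the step at this carbonyl carbon reads a number 6.6 percentage points higher from compound 1 to compound 4 (within the scatter) and gives the first comparison of two compounds that differ in one place. Replacing hydroxy with (2-chlorophenyl)amino adds an aromatic ring and eight heavy atoms in place of one, yet leaves the growth inhibition at this concentration within the scatter. No measured evidence bears on this result.

The compounds shown leave open whether phenylamino without the chlorine, or morpholine on the same carbonyl carbon, would also stay within the scatter.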